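The compounds below may be only part of what the source reports. "The series", "measured", "known", "first", "only" and "open" are said of these compounds alone.

Measured so far:
Compound 1, `O=C(CCl)Nc1ccc(C(=O)/C=C/c2ccccc2)cc1`, gives 2480 nM.
Compound 2, `O=C(CCl)Nc1ccc(C(=O)/C=C/c2ccccc2Cl)cc1`, gives 5260 nM.
Compound 3, `O=C(CSC(=S)N[C@H]1CCOC1=O)Nc1ccc(C(=O)/C=C/c2ccc(Cl)cc2)cc1`, gives 20300 nM.

These numbers come from a functional assay on MCF7 cells (Homo sapiens) for cytotoxicity, read by MTT assay, with a stated time of 72 h; on this read-out higher numbers stand for weaker inhibition and lower numbers for stronger inhibition. Compound 2 and compound 1 differ in one place: hydrogen in place of chloro on an aromatic carbon. The step of a 2.1-fold lower number from compound 2 to compound 1 (0.33 log units; beyond the scatter) shows that removing the chloro moved the number down by a modest amount. Compound 3 carries a different core, and how that core differs from the core of compound 2 is not broken down here; compound 3 stands furthest from compound 1 and nearest to compound 2 on this read-out.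

Compound 4, `O=C(CSC(=S)N[C@H]1CCOC1=O)Nc1ccc(C(=O)/C=C/c2ccccc2)cc1`, is not yet measured. It is made from compound 3 by hydrogen in place of chloro on an aromatic carbon. This is the same kind of change as from compound 2 to compound 1, but not the same: in compound 2 the chloro sits ortho to a large group, while in compound 3 it sits para to a large group. For the measured compounds named here, since only one earlier example exists, the expectation rests on it alone: the step of a 2.0-fold lower number from compound 3 to compound 4 (0.31 log units; beyond the scatter) is estimated to be roughly like the measured one, because a 2.1-fold lower number from compound 2 to compound 1 (0.33 log units; beyond the scatter) was modest. Compound 4 is therefore expected to give about 10000 nM in this assay, within a range of 4000 nM to 25000 nM.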

Compound 4, half-maximal inhibitory concentration: 44300 nM
Compound 4: middle estimate off by 4.4-fold (0.65 log units), on the low side, and the stated range ends below it.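

In this assay, taking off the chloro gives a 2.2-fold higher number from compound 3 to compound 4 (0.34 log units; beyond the scatter), while the same change lowered the number on the other core, so on these two cores the change does not carry over in its direction: the same change on two cores in this assay, a 2.1-fold lower number (0.33 log units; beyond the scatter) from compound 2 to compound 1 and a 2.2-fold higher number (0.34 log units; beyond the scatter) from compound 3 to compound 4, 4.6-fold (0.67 log units) apart, beyond the scatter of two such steps

Replacing the chlorine on the saturated chain carbon with the larger ring-bearing group gives an 18-fold higher number from compound 1 to compound 4 (1.25 log units; beyond the scatter), a large step showing that the choice of core can matter more here than the chloro does. These pairs do not show why the direction flips, and the chloro of compound 3, in its 4-chlorophenyl group, does not sit where the chloro of compound 2 sits, so core and chloro position change together and cannot be told apart.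

Going by these compounds, it remains open how a fluoro or a methoxy group in the place of the chloro would behave on either core. On these data alone, it also remains open whether an amine in place of the ring-bearing group would bring the number back toward that of compound 1.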